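The source may report more compounds than this note shows. Statements on the series, on what has been measured and on what is new or still open speak of the compounds shown alone.

Working notes on the diaryl urea series.

Three compounds have numbers in an assay on isolated protein for inhibition of acyl-CoA:cholesterol acyltransferase (Oryctolagus cuniculus); on this read-out higher numbers stand for weaker inhibition and lower numbers for stronger inhibition. Compound 1 `CCCCCCCCCCCCCc1ccc(NC(=O)Nc2c(C(C)C)cccc2C(C)C)cc1` gives 11 nM. Compound 2 `CC(C)c1cccc(C(C)C)c1NC(=O)Nc1ccccc1` gives 910 nM. Compound 3 `CC(C)c1cccc(C(C)C)c1NC(=O)Nc1ccc(C(C)(C)C)cc1` gives 168 nM, which puts compound 3 second highest of the three, nearest to compound 2 and furthest from compound 1. Among the compounds with values here, the one step between measured compounds that differ in one place is a 5.4-fold lower number from compound 2 to compound 3 (0.73 log units; beyond the scatter), a tert-butyl entering for a hydrogen.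

Compound 4 `CCCCCCCCCCCc1ccc(NC(=O)Nc2c(C(C)C)cccc2C(C)C)cc1` has not been measured. Against compound 3 the change is undecyl in place of tert-butyl on an aromatic carbon. Within the data shown here, no measured step covers this exchange directly. What bears on it is the pair of compound 1 and compound 3: compound 1, which carries a tridecyl chain at the same position, sits well below compound 3 in this assay, and the step from compound 2 to compound 3 already shows that a larger group at this carbon lowers the number. Undecyl is closer to tridecyl than to tert-butyl, so compound 4 is expected to land near compound 1, giving an expected step of an 11-fold lower number from compound 3 to compound 4 (1.05 log units; beyond the scatter) downward. The estimate for compound 4 is 15 nM, with a range from 5 nM to 45 nM.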

Compound 4, half-maximal inhibitory concentration: 9 nM
For compound 4 the middle estimate is 1.7-fold (0.22 log units) above the measured one; the measured number falls inside the stated range.
By their numbers in this assay, from the lowest: compounds 4 and 1 (each within the scatter of the next); then compound 3; then compound 2.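

In this assay the straight chain at this aromatic carbon goes much further than the branched group did: undecyl gives a far larger drop against tert-butyl (a 19-fold lower number from compound 3 to compound 4 (1.27 log units; beyond the scatter)) and against hydrogen (a 100-fold lower number from compound 2 to compound 4 (2.00 log units; beyond the scatter)) than tert-butyl gave against hydrogen (a 5.4-fold lower number from compound 2 to compound 3 (0.73 log units; beyond the scatter)). Undecyl and tridecyl cannot be told apart at this carbon (a 1.2-fold lower number from compound 1 to compound 4 (0.09 log units; within the scatter)), so over these two chains the extra length shows no effect on the number. No measurement shown here accounts for the size of these steps.

Open, on these data alone, is where between tert-butyl and undecyl the number falls, which a hexyl or octyl chain would help to place, and whether an octadecyl chain holds the same level. Also open, as far as these compounds go, is whether a carboxylic acid or an amine at the end of the undecyl chain is tolerated.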